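A few compounds are considered here, and "the series" means these few. Any claim that something is new, unique, unknown or untested is made for them only; others in the source may bear on it.

In an assay on MDA-MB-231 cells for binding affinity to C-X-C chemokine receptor type 4 (Homo sapiens), read by fluorescence and microscopy, with stated times of 10 min and 30 min (on this read-out lower numbers stand for an effect already at smaller amounts and higher numbers for an effect only at larger amounts of compound), the three measured compounds share one core and differ only in the aryl group on the sulfonyl sulfur. Compound 1 `Cc1ccccc1S(=O)(=O)NCc1ccc(CNC(=O)c2ccc(F)cc2)cc1` gives 100 nM. Compound 2 `Cc1cccc(S(=O)(=O)NCc2ccc(CNC(=O)c3ccc(F)cc3)cc2)c1` gives 1 nM, and compound 3 `O=C(NCc1ccc(CNS(=O)(=O)c2ccc(F)cc2)cc1)c1ccc(F)cc1` gives 1 nM. The two steps away from compound 1 are large: a 100-fold lower number from compound 1 to compound 2 (2.00 log units; beyond the scatter) and a 100-fold lower number from compound 1 to compound 3 (2.00 log units; beyond the scatter), both beyond the scatter, whereas no change at the digits printed from compound 2 to compound 3 (within the scatter). Compound 3 therefore stands level with compound 2 at the digits shown, the two together being the lowest numbers of the set, with compound 1 far behind.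

Compound 4 `O=C(NCc1ccc(CNS(=O)(=O)c2ccc(F)c(F)c2)cc1)c1ccc(F)cc1` is the next compound and is not yet measured. It differs from compound 3 by fluoro in place of hydrogen on an aromatic carbon. Among the measured compounds shown here, all three measured steps concern the same aryl ring on the sulfonyl sulfur, but none of them adds a second fluoro to the 4-fluorophenyl group, so the set holds no direct precedent. The nearest guidance is the step from compound 2 to compound 3, which exchanged one substitution pattern on that ring for another without any change beyond the scatter. A similar outcome is expected here: for compound 4 the estimate is 1.5 nM, between 0.5 nM and 5 nM, which would mean a 1.5-fold higher number from compound 3 to compound 4 (0.18 log units; within the scatter), a step not expected to exceed the scatter.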

Compound 4, effective concentration (reported as EC, without a stated level of effect): 10 nM
Compound 4: middle estimate off by 6.7-fold (0.82 log units), on the low side, outside the stated range (above it).
By their numbers in this assay, from the lowest: compounds 2 and 3 (each within the scatter of the next); then compound 4; then compound 1.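

In this assay, among the compounds shown here, a second fluoro on the 4-fluorophenyl group, ortho to a fluoro group and meta to a large group, gives a 10-fold higher number from compound 3 to compound 4 (1.00 log units; beyond the scatter), the first step in the set that starts from the 4-fluorophenyl group and goes beyond the scatter, so this aromatic carbon does not tolerate every change on that ring. The 3,4-difluorophenyl group also takes a place of its own among the aryl groups on the sulfonyl sulfur, with a 10-fold higher number from compound 2 to compound 4 (1.00 log units; beyond the scatter) and a 10-fold lower number from compound 1 to compound 4 (1.00 log units; beyond the scatter), so the set now spreads over three separate levels rather than two. The data shown offer no measurement that would explain this step.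

The compounds shown leave open whether the higher number belongs to fluoro itself or would follow any other group at this place, such as chloro, methoxy or an amine, and whether 3-fluorophenyl without the fluoro of compound 3 would behave like the 3,4-difluorophenyl group. They also leave open whether the step would keep its size if a carboxylic acid replaced the fluoro on the other aromatic ring of the shared core.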